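The source may hold more compounds than are shown below. What is called first, only, known or untested is meant among the compounds shown, and "the series" means these compounds.

Compound 1 `CC/C=C/C(=O)Nc1cccc(Oc2nc(Nc3ccn(C)n3)nc3c2CSCC3)c1` reaches only a limit in an ADME assay on L02 cells (Homo sapiens) for cytotoxicity, read by MTT assay, with a stated time of 72 h (a higher number here means a weaker inhibitor, a lower number a stronger inhibitor), > 50000 nM. For the measured compounds named here, compound 2 `C=C(F)C(=O)Nc1cccc(Oc2nc(Nc3ccn(C)n3)nc3c2CSCC3)c1` gives 47800 nM, the only actual number so far in this assay. Compound 3 `C=C(C)C(=O)Nc1cccc(Oc2nc(Nc3ccn(C)n3)nc3c2CSCC3)c1` has methyl in place of fluoro on a double-bonded chain carbon bound to a carbonyl carbon. Going by the values given here, only one measured step bears on this change, an at least 1.0-fold lower number from compound 1 to compound 2 (0.01 log units; that floor lies within the scatter), and it changes a different group on the same carbonyl carbon. Among the compounds with values here, with that step as the only guide, no change beyond the scatter is expected, and the expected step is a 1.0-fold higher number from compound 2 to compound 3 (0.00 log units; within the scatter). Compound 3 is estimated at 48000 nM, with an expected range of 25000 nM to 90000 nM.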

Compound 3, half-maximal inhibitory concentration: > 50000 nM
Compound 3: a limit, no number; the forecaster's own chance of this, stated with the estimate: 50%; middle value at least 1.0-fold (0.01 log units) from the limit.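

In this assay, methyl in place of fluoro on a double-bonded chain carbon bound to a carbonyl carbon gives an at least 1.0-fold higher number from compound 2 to compound 3 (0.01 log units; that floor lies within the scatter). The value of compound 3 is a limit and not a number, and the step linking the two limits of the other pair cannot be read. Across these changes on the carbonyl carbon, no step is shown beyond the scatter, and the result adds a second compound at the limit: the limit of > 50000 nM in this assay, at which 2 of the 3 values shown sit.

Going by these compounds, it remains open whether an amine or a carboxylic acid on the double-bonded chain carbon would move the number beyond the scatter from compound 2.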